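Methoxy to hydroxy on the chlorophenyl of compound 2

This account rests on a few compounds, and the source may have more. Where it says the series, first, only, none or still open, it means among the compounds named here.

Two compounds carry numbers in a functional assay on SR cells (Homo sapiens) for inhibition, read by sulforhodamine B assay, with a stated time of 48 h; a higher number here means a weaker inhibitor of growth, a lower number a stronger inhibitor of growth. Compound 2 `COc1cc(-c2nn(-c3cccc(NC(=O)Nc4ccc(Cl)c(Cl)c4)c3)cc2-c2ccncc2)ccc1Cl` gives 2800 nM in this assay, the lower of the two values; compound 1 `O=C(Nc1cccc(-n2cc(-c3ccncc3)c(-c3ccc(Cl)c(O)c3)n2)c1)Nc1cccc(C(F)(F)F)c1` gives 20000 nM, and the gap between them lies well beyond the scatter. Compound 3 `O=C(Nc1cccc(-n2cc(-c3ccncc3)c(-c3ccc(Cl)c(O)c3)n2)c1)Nc1ccc(Cl)c(Cl)c1` is compound 2 with a single change: hydrogen in place of methyl on an oxygen on an aromatic ring, so that the 4-chloro-3-methoxyphenyl becomes a 4-chloro-3-hydroxyphenyl. Within the data shown here, no pair among the measured compounds isolates this change, so there is no measured step to lean on. With nothing in the data to favour one direction, the expected step from compound 2 to compound 3 is a 1.6-fold higher number from compound 2 to compound 3 (0.21 log units; within the scatter), which may well amount to no change beyond the scatter, and the range is kept wide. The estimate for compound 3 in this assay is 4500 nM, with a range from 1500 nM to 14000 nM.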

Compound 3, concentration for total growth inhibition: 15000 nM
Beside the measured number, compound 3's estimate is 3.3-fold (0.52 log units) below it, and the stated range ends below it.
By their numbers in this assay, from the lowest: compound 2; then compounds 3 and 1 (each within the scatter of the next).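

In this assay, among these compounds, hydroxy in place of methoxy gives a 5.4-fold higher number from compound 2 to compound 3 (0.73 log units; beyond the scatter), the first reading of this change with the rest of the structure held fixed, and it shows that the methyl on this oxygen cannot be removed without a measurable loss of growth inhibition. With the 4-chloro-3-hydroxyphenyl held in place, 3,4-dichlorophenyl in place of 3-(trifluoromethyl)phenyl on the amide-type nitrogen gives a 1.3-fold lower number from compound 1 to compound 3 (0.12 log units; within the scatter), so that exchange has no effect beyond the scatter in this setting. Nothing among the data accounts for the loss on going from methoxy to hydroxy.

Open, as far as these compounds go, is whether a longer alkoxy chain such as ethoxy, or an amine on the aromatic ring in place of the oxygen, would keep the value of the methoxy compound. Also open, from the compounds shown here alone, is whether the two aryl groups on the urea stay interchangeable when methoxy is present.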